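The compounds below may be only part of what the source reports. "The series", "measured", "known", "first", "only" and "open" are said of these compounds alone.

Working notes on the series. Compound 1 `O=C1CCC(N2C(=O)c3ccc(Nc4ccccc4)cc3C2=O)C(=O)N1` carries only hydrogen at the aromatic carbon of interest; in an assay on FRT-Jurkat cells for inhibition of nuclear factor NF-kappa-B complex (Homo sapiens), read by flow cytometry, with a stated time of 24 h, tested at 10 uM (on this read-out lower numbers stand for less inhibition and higher numbers for more inhibition at the one concentration tested (going by the name of the read-out)), compound 1 gives 6%. Compound 2 `O=C1CCC(N2C(=O)c3ccc(Nc4ccc(O)cc4)cc3C2=O)C(=O)N1` carries hydroxy there, and in this assay compound 2 gives 4%. Compound 3 `CCCc1ccc(Nc2ccc3c(c2)C(=O)N(C2CCC(=O)NC2=O)C3=O)cc1` carries propyl there, and in this assay compound 3 gives 10%. Compound 3 holds the highest of the three numbers, yet every step that reaches it stays within the scatter: a number 4 percentage points higher from compound 1 to compound 3 (within the scatter) and a number 6 percentage points higher from compound 2 to compound 3 (within the scatter), as does the step between the other two, a number 2 percentage points lower from compound 1 to compound 2 (within the scatter). Nothing among these three moves the read-out.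

Compound 4 `COc1ccc(Nc2ccc3c(c2)C(=O)N(C2CCC(=O)NC2=O)C3=O)cc1` is the next entry: methoxy in place of propyl on an aromatic carbon. For the measured compounds named here, no measured step exchanges propyl for methoxy. The closest comparison is the exchange of an oxygen-bearing group for propyl, a number 6 percentage points higher from compound 2 to compound 3 (within the scatter), which was within the scatter, and the exchange of hydrogen for propyl, a number 4 percentage points higher from compound 1 to compound 3 (within the scatter), also within the scatter. Compound 4 is therefore expected to show no step beyond the scatter, a number 3 percentage points lower from compound 3 to compound 4 (within the scatter). The estimate for compound 4 in this assay is 7%, with a range of -3% to 17%.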

Compound 4, a percentage reported as inhibition, at one concentration (the size of the read-out at that concentration, not a potency): 29%
Compound 4: the middle estimate sits 22 percentage points below what was measured, outside the stated range (above it).
By their numbers in this assay, from the lowest: compounds 2, 1 and 3 (each within the scatter of the next); then compound 4.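

In this assay, for the compounds shown here, the aromatic carbon para to a large group is not silent after all: methoxy gives the first steps beyond the scatter (a number 19 percentage points higher from compound 3 to compound 4 (beyond the scatter); a number 23 percentage points higher from compound 1 to compound 4 (beyond the scatter); a number 25 percentage points higher from compound 2 to compound 4 (beyond the scatter)). The last of these steps is only methyl in place of hydrogen on the oxygen, and since hydroxy in compound 2 stays within the scatter of hydrogen in compound 1, an oxygen on this carbon does not by itself go with the higher number; among these compounds, only the methoxy of compound 4 does. No measurement available here explains why methoxy stands apart from hydroxy, propyl and hydrogen.

Going by these compounds, whether ethoxy or a longer ether chain would hold or raise the number of compound 4 remains open. So does the outcome for an amine or a carboxylic acid at this carbon.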